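The source may hold more compounds than are shown below. What is called first, only, known or untested is meant among the compounds shown, and "the series" means these compounds.

In a functional assay on MCF7 cells (Homo sapiens) for inhibition, read by fluorescence, with a stated time of 72 h (a higher number here means a weaker inhibitor, a lower number a stronger inhibitor), three compounds on the shared core have measured values. Compound 1 `CC[C@H](N)COc1nc(NC(=N)N)c2ncn(C(C)C)c2n1` gives 16300 nM, compound 2 `CC(C)[C@@H](N)COc1nc(NC(=N)N)c2ncn(C(C)C)c2n1` gives 79400 nM and compound 3 `CC(C)[C@H](CO)Nc1nc(NC(=N)N)c2ncn(C(C)C)c2n1` gives 10500 nM. Compound 3 is not separated from compound 1, with a 1.6-fold lower number from compound 1 to compound 3 (0.19 log units; within the scatter), but stands clear of compound 2, with a 7.6-fold lower number from compound 2 to compound 3 (0.88 log units; beyond the scatter).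

Compound 4 `CC(C)[C@@H](CO)Nc1nc(NC(=N)N)c2ncn(C(C)C)c2n1` keeps the structure of compound 3 and alters only its drawn configuration: the two compounds have the same atoms and bonds; at least one stereo element is drawn with a configuration in one of them and without one in the other: 1 of 2 stereo elements differ; a stereocentre at a saturated chain carbon is drawn R in compound 3 and S in compound 4.

Within the data shown here, no measured pair isolates a change of configuration, so the evidence on size is indirect. The closest guides are the changes in the side chain, with a 4.9-fold higher number from compound 1 to compound 2 (0.69 log units; beyond the scatter) alongside the step from compound 2 already given. These suggest a step no larger than modest in this assay. The data do not fix its direction, and only a slight lean towards a higher number is expected. The estimated step is a 1.7-fold higher number from compound 3 to compound 4 (0.23 log units; within the scatter). For compound 4, the expected value is 18000 nM, with an estimated range of 6000 nM to 55000 nM.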

Compound 4, half-maximal inhibitory concentration: 2100 nM
For compound 4 the middle estimate is 8.6-fold (0.93 log units) above the measured one, outside the stated range (below it).
By their numbers in this assay, from the lowest: compound 4; then compounds 3 and 1 (each within the scatter of the next); then compound 2.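

In this assay, among these compounds, the drawn configuration at the saturated chain carbon proves to matter, and this is the first pair to isolate it: a 5.0-fold lower number from compound 3 to compound 4 (0.70 log units; beyond the scatter), with the S form giving the lower number. In this configuration, the (1-(hydroxymethyl)-2-methylpropyl)amino group stands clear of both 2-aminobutoxy, with a 7.8-fold lower number from compound 1 to compound 4 (0.89 log units; beyond the scatter), and 2-amino-3-methylbutoxy, with a 38-fold lower number from compound 2 to compound 4 (1.58 log units; beyond the scatter), making compound 4 the strongest inhibitor of the four, whereas compound 3 was not separated from compound 1. The step from the configuration change carries one qualification: the fact that one of compounds 3 and 4 is drawn with a defined configuration and the other without, at the place where they differ.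

The compounds shown leave open whether the configuration at the saturated chain carbon has a similar effect on the 2-aminobutoxy and 2-amino-3-methylbutoxy chains. Also open, as far as these compounds go, is how a carboxylic acid or a longer chain in place of the hydroxymethyl group would behave in the S form.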